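Biaryl sulfonamide series: aryl substituent and liver half-life

A few compounds are considered here, and "the series" means these few. Any claim that something is new, unique, unknown or untested is made for them only; others in the source may bear on it.

Compound 1 `CC1CCN(C2CCN(S(=O)(=O)c3cccc(-c4ccc(F)cc4)c3)CC2)CC1` gives 1.28 h in an ADME assay on S9 fraction from liver (Mus musculus, strain ICR/CD-1) for metabolic stability, read by LC-MS, using NADPH, with a stated time of 5 min, tested at 2 uM; on this read-out lower numbers stand for a shorter-lived compound and higher numbers for a longer-lived compound. Compound 2 `CC1CCN(C2CCN(S(=O)(=O)c3cccc(-c4ccccc4C(F)(F)F)c3)CC2)CC1` gives 0.617 h in this assay, a 2.1-fold lower number from compound 1 to compound 2 (0.32 log units; beyond the scatter). Compound 3 `Cc1cc(C)cc(-c2cccc(S(=O)(=O)N3CCC(N4CCC(C)CC4)CC3)c2)c1` reaches the limit of this assay, > 4 h, (the limit of > 4 h in this assay, at which 1 of the 3 values shown sits). Compound 3 thus stands at the longest-lived end of the three numbers shown, with an at least 3.1-fold higher number from compound 1 to compound 3 (0.49 log units; beyond the scatter) and an at least 6.4-fold higher number from compound 2 to compound 3 (0.81 log units; beyond the scatter). Compound 4 `Cc1ccc(-c2cccc(S(=O)(=O)N3CCC(N4CCC(C)CC4)CC3)c2)cc1` differs from compound 3 by 4-methylphenyl in place of 3,5-dimethylphenyl on an aromatic carbon. Going by the values given here, no measured step removes one methyl from this aryl ring; the steps from compound 1 and from compound 2 into compound 3 show that this aryl group moves the half-life at least modestly, so a modest fall from the limit is expected. For compound 4 the expected step is an at least 1.3-fold lower number from compound 3 to compound 4 (0.12 log units; that floor lies within the scatter). Compound 4 is expected to give 3 h, within 1.2 h to 7.5 h.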

Compound 4, half-life: 1.92 h
Estimate against measurement, compound 4: 1.6-fold (0.19 log units) above; the range from low to high includes it.
By their numbers in this assay, from the lowest: compound 2; then compounds 1 and 4 (each within the scatter of the next). At a limit, above all of these: compound 3.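

With 4-methylphenyl in place of 3,5-dimethylphenyl, this assay shows an at least 2.0-fold lower number from compound 3 to compound 4 (0.31 log units; beyond the scatter), so the half-life at this position responds to a change between two methyl-bearing aryl groups, not only to changes from the fluorinated ones. The 4-methylphenyl group still gives a 3.1-fold higher number from compound 2 to compound 4 (0.49 log units; beyond the scatter), whereas methyl in place of fluoro gives a 1.5-fold higher number from compound 1 to compound 4 (0.18 log units; within the scatter). The first step is only a floor, as compound 3 stands at a limit: the limit of > 4 h in this assay, at which 1 of the 4 values shown sits.

On these data alone, whether 3,5-dimethoxyphenyl would also reach that limit stays open. The size of the true drop from compound 3 also cannot be told.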